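A methyl for a methoxy on the amide nitrogen

The source may report more compounds than this note shows. Statements on the series, on what has been measured and on what is new or still open speak of the compounds shown alone.

Compound 1, `COc1ccc(NC(=O)c2cccc(/C=C3\CC(=O)N(c4ccccc4)C3=O)c2)cc1`, was tested in an ADME assay on NCM460 cells (Homo sapiens) for cytotoxicity, read by MTT assay, with a stated time of 72 h; on this read-out higher numbers stand for weaker inhibition and lower numbers for stronger inhibition. There compound 1 gives > 100000 nM, which is a limit of the assay rather than a number. Compound 2, `CCCCCN1C(=O)C/C(=C\c2cccc(C(=O)NCCCC)c2)C1=O`, gives > 100000 nM in this assay, again only a limit. Compound 3, `CCCCCN1C(=O)C/C(=C\c2cccc(C(=O)Nc3cccc(CC)c3)c2)C1=O`, gives > 100000 nM in this assay, also a limit. For the measured compounds named here, the single step measured between compounds that differ in one place, a step that the two limits leave unreadable from compound 2 to compound 3, therefore cannot be sized, and all the evidence gathers at the limit of > 100000 nM in this assay, at which 3 of the 3 values shown sit.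

Compound 4, `Cc1cccc(NC(=O)c2cccc(/C=C3\CC(=O)N(c4ccccc4)C3=O)c2)c1`, has not yet been measured in this assay. It differs from compound 1 by 3-methylphenyl in place of 4-methoxyphenyl on an amide-type nitrogen. Going by the values given here, no measured step bears on this exchange, and the limits leave no step readable at all, so the data give no ground to expect movement beyond the scatter in either direction. Compound 4 is expected to sit where compound 1 sits, most likely as a further limit. The step from compound 1 to compound 4 is estimated as a step that the limit leaves unreadable from compound 1 to compound 4. Compound 4 is accordingly estimated at 150000 nM, within a range from 50000 nM to 500000 nM, with the measurement itself likely to return only a limit.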

Compound 4, half-maximal inhibitory concentration: > 100000 nM
Compound 4: a limit, no number; the forecaster's own chance of this, stated with the estimate: 85%; the middle value is on the limit's open side.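

In this assay compound 4 gives > 100000 nM which is a limit and not a number. For the compounds shown here, compound 1 also stands at a limit, so no step from compound 1 to compound 4 can be read. The compounds shown leave open whether any group on the amide-type nitrogen would give a measurable value in this assay and how far each compound lies beyond the limit: the limit of > 100000 nM in this assay, at which 4 of the 4 values shown sit.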